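Swapping a Chlorophenyl for an Indole on a Hydrazone

The compounds below may be only part of what the source reports. "The series", "measured", "known", "first", "only" and "open" are said of these compounds alone.

Compound 1, `CCCSc1nc(N/N=C/c2cc(OC)c(OC)c(OC)c2)c2nnn(Cc3ccccc3)c2n1`, gives > 64000 nM in a functional assay on MCF7 cells (Homo sapiens) for antiproliferative activity, read by MTT assay, with a stated time of 72 h (a lower number here means a stronger inhibitor, a higher number a weaker inhibitor), which is a limit of the assay rather than a number.
Compound 2, `CCCSc1nc(N/N=C/c2ccc(Cl)cc2)c2nnn(Cc3ccccc3)c2n1`, gives > 64000 nM, again only a limit.

Compound 2 therefore stands at the limit, where both values sit (the limit of > 64000 nM in this assay, at which 2 of the 2 values shown sit). Compound 3, `CCCSc1nc(N/N=C/c2c[nH]c3ccccc23)c2nnn(Cc3ccccc3)c2n1`, differs from compound 2 by 1H-indol-3-yl in place of 4-chlorophenyl on a carbon with a double bond to nitrogen. Going by the values given here, with no measured step between two numbered values to lean on, the expected step that the limit leaves unreadable from compound 2 to compound 3 is none beyond the scatter. Compound 3 is expected to remain around 100000 nM, with a range from 30000 nM to 400000 nM, most likely reported again as a limit.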

Compound 3, half-maximal inhibitory concentration: 9010 nM
Compound 3: middle estimate off by 11-fold (1.05 log units), on the high side; the whole stated range lies above it.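

In this assay, 1H-indol-3-yl in place of 4-chlorophenyl on a carbon with a double bond to nitrogen gives an at least 7.1-fold lower number from compound 2 to compound 3 (0.85 log units; beyond the scatter). This shows that a change at this one place can bring a compound off the limit and give a real number. The true size of the step cannot be read, because compound 2 has only a limit: the limit of > 64000 nM in this assay, at which 2 of the 3 values shown sit.

Which part of 1H-indol-3-yl counts, its five-membered ring or its hydrogen-bond donor, stays open. So does whether an indole with a methyl group on its nitrogen, or a phenyl ring carrying an amine, would behave the same way.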